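A few compounds are considered here, and "the series" means these few. Any claim that something is new, unique, unknown or untested is made for them only; others in the source may bear on it.

The measured compounds:

compound 1, `O=S(=O)(NCC1CCN(CCCc2c[nH]c3ccc(-n4cnnc4)cc23)CC1)c1ccccc1`, 12 nM
compound 2, `c1ccc(CNC2CCN(CCCc3c[nH]c4ccc(-n5cnnc5)cc34)CC2)cc1`, 7.6 nM
compound 3, `COC[C@H](NC1CCN(CCCc2c[nH]c3ccc(Cn4cncn4)cc23)CC1)c1ccc(F)cc1`, 8.9 nM

All three were run in an assay on CHO cells for agonist activity at 5-hydroxytryptamine receptor 1D (Homo sapiens), read by GTPgammaS binding; on this read-out higher numbers stand for an effect only at larger amounts of compound and lower numbers for an effect already at smaller amounts. The three numbers sit close together: compound 2 has the lowest of them, but its gap to compound 3 and its gap to compound 1 are both within the scatter, so no ordering among them can be claimed.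

Compound 4, `CC(=O)Nc1ccc(CNC2CCN(CCCc3c[nH]c4ccc(-n5cnnc5)cc34)CC2)cc1`, is the next compound and has not yet been measured. It differs from compound 2 in one place: acetamido in place of hydrogen on an aromatic carbon.

Among the measured compounds shown here, only one measured step exists, a 1.6-fold lower number from compound 1 to compound 2 (0.20 log units; within the scatter). That step changed the link between the saturated ring and the phenyl, not a substituent on the phenyl itself, so it bears on the present change only indirectly; what it shows is that a reworking in this outer region left the number within the scatter. Nothing measured speaks to acetamido on the aromatic carbon, and compound 3, which carries a fluorine on its own aromatic ring, gives 8.9 nM, again within the scatter of compound 2.

On this basis a step of a 1.1-fold higher number from compound 2 to compound 4 (0.02 log units; within the scatter) is expected, that is, none beyond the scatter. Compound 4 is therefore estimated at 8 nM, with a range from 3 nM to 25 nM.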

Compound 4, half-maximal effective concentration: 5 nM
Compound 4: the middle estimate sits 1.6-fold (0.20 log units) above what was measured; measured number inside the range.
By their numbers in this assay, from the lowest: compounds 4, 2, 3 and 1 (each within the scatter of the next, the first and the last beyond it).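

In this assay, acetamido in place of hydrogen on the aromatic carbon para to a large group gives a 1.5-fold lower number from compound 2 to compound 4 (0.18 log units; within the scatter), so turning phenyl into 4-acetamidophenyl leaves the number within the scatter. The earlier step concerned only the link between the saturated ring and the phenyl, whereas this one puts a substituent on the phenyl itself and shows that this aromatic carbon can carry a group as large as acetamido with no change beyond the scatter in this assay. No measurement shown here offers an explanation for this outcome, and a single substitution cannot separate what the carbonyl and the amide hydrogen each contribute.

As far as these compounds go, it remains open whether other groups on this carbon, such as an amine, a carboxylic acid or a longer acyl chain like propionamido, would also keep the number within the scatter of compound 2. From the compounds shown here alone, it is also open whether acetamido would give the same result on another carbon of the same ring, or whether an N-methylacetamido group, which lacks the amide hydrogen, would do so on this one.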